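The source may report more compounds than this note shows. Statements on the series, on what has been measured and on what is new or still open speak of the compounds shown alone.

In a functional assay on MDA-MB-231 cells (Homo sapiens), read by microscopy and transwell migration, with a stated time of 24 h (on this read-out lower numbers stand for stronger inhibition and higher numbers for weaker inhibition), compound 1 (`CCn1c(-c2ccc(C)cc2C)cs/c1=N\C(=O)c1ccccc1`) gives 1950 nM and compound 2 (`C#CCn1c(-c2ccccc2)cs/c1=N\C(=O)c1ccccc1`) gives 2780 nM, two values within the usual scatter of each other. For compound 3 (`COc1cc(-c2csc(NC(=O)c3ccc(Cl)cc3)n2)cc(OC)c1OC`), this assay returns > 25000 nM, which is a limit of the assay and not a number. Compound 4 (`COc1cccc(C(=O)Nc2nc(-c3cc(OC)c(OC)c(OC)c3)cs2)c1`) differs from compound 3 in one place, with 3-methoxyphenyl in place of 4-chlorophenyl on a carbonyl carbon. For the measured compounds named here, no measured pair in this small set shows what such an exchange does, so any forecast remains tentative. No step beyond the scatter, in either direction, is expected in this assay, and the reading for compound 4 is expected to stay close to the limit of compound 3 at > 25000 nM. The estimated change is a step that the limit leaves unreadable from compound 3 to compound 4, and it may well be reported only as a limit again. The expected value for compound 4 is 28000 nM, with an estimated range of 10000 nM to 70000 nM.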

Compound 4, half-maximal inhibitory concentration: 14000 nM
The estimate for compound 4 lay 2.0-fold (0.30 log units) above the measured number, and the stated range covers the measured number.
By their numbers in this assay, from the lowest: compounds 1 and 2 (each within the scatter of the next); then compound 4. At a limit, above all of these: compound 3.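

In this assay, for the compounds shown here, 3-methoxyphenyl in place of 4-chlorophenyl on a carbonyl carbon gives an at least 1.7-fold lower number from compound 3 to compound 4 (0.25 log units; that floor lies within the scatter), the first reading of a change at this position. Compound 4 carries a number where compound 3 carries only a limit, yet the floor of the step lies within the scatter, so this pair alone does not establish a real change. The full size of the step cannot be read because the value of compound 3 is a limit of the assay and not a number: the limit of > 25000 nM in this assay, at which 1 of the 4 values shown sits.

The pair leaves open whether the methoxy group or the loss of the chlorine carries the change, and how an amine or a carboxylic acid on that phenyl ring would read on the same carbonyl carbon. Compound 1 and compound 2 differ from compound 4 in more than one place, so they offer no comparison.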